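Methyl added on the chain carbon of a formamide purine

The source may report more compounds than this note shows. Statements on the series, on what has been measured and on what is new or still open speak of the compounds shown alone.

Measured compounds:
Compound 1, `CC(C1CC1)n1cnc2c(NC3CC3)ncnc21` — in a functional assay on the whole organism for antagonist activity, with Rattus norvegicus as the target (a higher number here means that more compound is needed for the effect, a lower number that less compound is needed), compound 1 gives 9 mg/kg; 25 mg/kg; > 25 mg/kg (3 entries).
Compound 2, `O=CN(c1ncnc2c1ncn2CC1CC1)C1CC1` — in this assay compound 2 gives 30 mg/kg.

Compound 1 has several entries in this assay, and one of them is a limit of the assay rather than a number. Within the data shown here, compound 2 stands at 30 mg/kg, the only number for it; a further entry gives no single number. Compound 1 and compound 2 differ in more than one place, so their values are simply two readings side by side.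

Compound 3, `CC(C1CC1)n1cnc2c(N(C=O)C3CC3)ncnc21`, is not yet measured. It differs from compound 2 by methyl in place of hydrogen on a saturated chain carbon bound to an aromatic nitrogen and a saturated ring carbon. Among the measured compounds shown here, no measured pair shows this change on its own. Compound 3 is expected to sit close to compound 2, with the step of a 1.4-fold lower number from compound 2 to compound 3 (0.13 log units; within the scatter) estimated to lie within the scatter. Compound 3 is expected to give 22 mg/kg, in a range from 7 mg/kg to 60 mg/kg.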

Compound 3, dose for half-maximal effect: 7.5 mg/kg
Compound 3: middle estimate off by 2.9-fold (0.47 log units), on the high side; the range from low to high includes it.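

The change from cyclopropylmethyl to 1-cyclopropylethyl now has a reading of its own in this assay: methyl in place of hydrogen on a saturated chain carbon bound to an aromatic nitrogen and a saturated ring carbon gives a 4.0-fold lower number from compound 2 to compound 3 (0.60 log units; beyond the scatter). This position therefore responds to a single added carbon, with less compound needed for the effect, something the two earlier compounds could not show while they differed in more than one place. The step rests on one number for each compound and is only modest, and repeated entries can spread widely in this whole-animal setting, as compound 1 shows, one of its entries being a limit of the assay and not a number: the several entries of compound 1 in this assay, 9 mg/kg; 25 mg/kg; > 25 mg/kg (3 entries).

The compounds shown leave open whether a different group on this chain carbon, such as hydroxymethyl or a longer propyl chain, would shift the dose further in either direction. They also leave open whether the methyl has the same effect when the formyl group on the cyclopropylamino nitrogen is replaced by an acetyl group.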